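This account rests on a few compounds, and the source may have more. Where it says the series, first, only, none or still open, it means among the compounds named here.

In an ADME assay on HEK-293T cells (Homo sapiens) for cytotoxicity, read by CCK-8 assay, with a stated time of 48 h (a lower number here means a stronger inhibitor, a higher number a weaker inhibitor), compound 1 (`O=C(NCCNS(=O)(=O)c1ccc(-c2ccccc2O[C@H]2CC[C@@H](O)CC2)s1)Nc1ccc([N+](=O)[O-])cc1`) gives 8600 nM and compound 2 (`O=C(NCCNS(=O)(=O)c1ccc(-c2ccccc2O[C@H]2CC[C@H](O)CC2)s1)Nc1ccc([N+](=O)[O-])cc1`) gives 9000 nM. Between this pair the measured step is a 1.0-fold higher number from compound 1 to compound 2 (0.02 log units; within the scatter), and what separates them is the fact that compounds 1 and 2 differ only in the configuration as drawn. Compound 3 (`O=C(NCCNS(=O)(=O)c1ccc(-c2ccccc2Oc2ccc([N+](=O)[O-])c([N+](=O)[O-])c2)s1)Nc1cc(Cl)cc(Cl)c1`) reads > 20000 nM, which is a limit of the assay and not a number. Compound 4 (`O=C(NCCNS(=O)(=O)c1ccc(-c2ccccc2Oc2ccc([N+](=O)[O-])c([N+](=O)[O-])c2)s1)Nc1ccc([N+](=O)[O-])cc1`) differs from compound 3 in one place: 4-nitrophenyl in place of 3,5-dichlorophenyl on an amide-type nitrogen. For the measured compounds named here, no measured step covers this change, since the only one available concerns configuration. Compound 2 carries the same 4-nitrophenyl on an amide-type nitrogen and reads 9000 nM, so a modest move towards a lower number is expected, though on a different core. The expected step is an at least 1.6-fold lower number from compound 3 to compound 4 (0.22 log units; that floor lies within the scatter). For compound 4 the estimated value is 12000 nM, with an expected range of 5000 nM to 25000 nM.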

Compound 4, half-maximal inhibitory concentration: 16600 nM
Estimate against measurement, compound 4: 1.4-fold (0.14 log units) below, within the range that was stated.
By their numbers in this assay, from the lowest: compounds 1, 2 and 4 (each within the scatter of the next). At a limit, above all of these: compound 3.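

In this assay compound 3 reads > 20000 nM, a limit of the assay and not a number. On an amide-type nitrogen, 4-nitrophenyl in place of 3,5-dichlorophenyl gives an at least 1.2-fold lower number from compound 3 to compound 4 (0.08 log units; that floor lies within the scatter), so only a floor is known and it does not separate the pair. On an oxygen on an aromatic ring, 3,4-dinitrophenyl in place of 4-hydroxycyclohexyl gives a 1.8-fold higher number from compound 2 to compound 4 (0.27 log units; within the scatter) and a 1.9-fold higher number from compound 1 to compound 4 (0.29 log units; within the scatter), so neither step separates its pair in this assay. As far as these compounds go, the full size of the step at the amide-type nitrogen stays open. Also open, from the compounds shown here alone, is whether a carboxylic acid or a morpholine on the oxygen would give a step beyond the scatter.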